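Taking the methoxy group off compound 2

The compounds below may be only part of what the source reports. "The series", "measured", "known", "first", "only" and "open" are said of these compounds alone.

Compound 1 `CC1(C)[C@H]2CC[C@]1(C)N(Cc1cn(-c3cccc(C#N)c3)nn1)C(=O)C2` gives 440 nM
Compound 2 `COc1ccccc1-n1cc(CN2C(=O)C[C@@H]3CC[C@@]2(C)C3(C)C)nn1` gives 350 nM

In a functional assay on A549 cells (Homo sapiens) for inhibition, read by MTT assay, with a stated time of 24 h (a lower number here means a stronger inhibitor, a higher number a weaker inhibitor), compound 2 (350 nM) stands within the scatter of compound 1 (440 nM). Compound 3 `CC1(C)[C@H]2CC[C@]1(C)N(Cc1cn(-c3ccccc3)nn1)C(=O)C2` has hydrogen in place of methoxy on an aromatic carbon. Within the data shown here, only one measured step bears on this change, and it also concerns the aromatic group: 2-methoxyphenyl in place of 3-cyanophenyl (a 1.3-fold lower number from compound 1 to compound 2 (0.10 log units; within the scatter)). That step stayed within the scatter, so no shift beyond the scatter is expected in this assay. The expected step (a 1.1-fold higher number from compound 2 to compound 3 (0.06 log units; within the scatter)) is an estimate only. Compound 3 is estimated at 400 nM (expected range 150 nM to 1000 nM).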

Compound 3, half-maximal inhibitory concentration: 70 nM
Beside the measured number, compound 3's estimate is 5.7-fold (0.76 log units) above it; measured number outside the range, below it.
By their numbers in this assay, from the lowest: compound 3; then compounds 2 and 1 (each within the scatter of the next).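

In this assay, among these compounds, the change to plain phenyl is the first to move the number beyond the scatter: hydrogen in place of methoxy gives (a 5.0-fold lower number from compound 2 to compound 3 (0.70 log units; beyond the scatter)), and hydrogen in place of cyano gives (a 6.3-fold lower number from compound 1 to compound 3 (0.80 log units; beyond the scatter)). The earlier flat step between 2-methoxyphenyl and 3-cyanophenyl therefore hid a shared gap, with both substituted compounds standing above the unsubstituted compound 3. Nothing available explains this gap.

On these data alone, whether a fluorine atom or a methyl group on this ring would keep the number of compound 3 stays open. So does whether the group itself or its place on the ring matters more.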